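The compounds below may be only part of what the source reports. "The series", "measured", "known", "first", "only" and "open" are said of these compounds alone.

Measured in a functional assay (aorta) with Rattus norvegicus as the target; on this read-out lower numbers stand for an effect already at smaller amounts and higher numbers for an effect only at larger amounts of compound:
- compound 1 `COc1ccc(-c2nc(CN(C)C)sc2-c2ccc(OC)cc2)cc1`: 8.4 uM
- compound 2 `COc1ccc(-c2nc(CNC(=O)CSC)sc2-c2ccc(OC)cc2)cc1`: 6 uM
- compound 3 `COc1ccc(-c2nc(CNC(=O)N3CCOCC3)sc2-c2ccc(OC)cc2)cc1`: 12 uM

Compound 3 stands within the scatter of both other compounds, with a 1.4-fold higher number from compound 1 to compound 3 (0.15 log units; within the scatter) and a 2.0-fold higher number from compound 2 to compound 3 (0.30 log units; within the scatter). Compound 4 `COc1ccc(-c2nc(CNC(=O)NC(C)C)sc2-c2ccc(OC)cc2)cc1` differs from compound 3 in one place, with isopropylamino in place of morpholin-4-yl on a carbonyl carbon. For the measured compounds named here, no measured step makes this exact swap. The closest is a 2.0-fold higher number from compound 2 to compound 3 (0.30 log units; within the scatter), which also changes the group on a carbonyl carbon. The other two steps, a 1.4-fold lower number from compound 1 to compound 2 (0.15 log units; within the scatter) and a 1.4-fold higher number from compound 1 to compound 3 (0.15 log units; within the scatter), change the group on a saturated chain carbon, and they too stay within the scatter. No step beyond the scatter is therefore expected in this assay. The estimated step is a 1.2-fold lower number from compound 3 to compound 4 (0.08 log units; within the scatter). For compound 4 the expected value is 10 uM, with an estimated range from 4.5 uM to 22 uM.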

Compound 4, concentration for half-maximal effect: 5.7 uM
For compound 4 the middle estimate is 1.8-fold (0.24 log units) above the measured one, and the stated range covers the measured number.
By their numbers in this assay, from the lowest: compounds 4, 2, 1 and 3 (each within the scatter of the next, the first and the last beyond it).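

In this assay, for the compounds shown here, isopropylamino in place of morpholin-4-yl on a carbonyl carbon gives a 2.1-fold lower number from compound 3 to compound 4 (0.32 log units; beyond the scatter), the first step in this set to pass the usual scatter, though only modestly. The other two steps, a 1.1-fold lower number from compound 2 to compound 4 (0.02 log units; within the scatter) and a 1.5-fold lower number from compound 1 to compound 4 (0.17 log units; within the scatter), stay within the scatter, so this swap separates the two ends of a narrow range without setting the new compound apart from the rest. Nothing measured here accounts for this step.

From the compounds shown here alone, it remains open whether piperidin-1-yl or cyclopropylamino on this carbonyl carbon would stand nearer compound 3 or compound 4.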